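A few compounds are considered here, and "the series" means these few. Any claim that something is new, unique, unknown or untested is made for them only; others in the source may bear on it.

Measured compounds in a functional assay on A549 cells (Homo sapiens) for inhibition, read by sulforhodamine B assay, with a stated time of 48 h, tested at 10 uM; a lower number here means less inhibition, a higher number more inhibition at the concentration tested (going by the name of the read-out): compound 1 `Brc1cn2ccnc2c(-c2ccc3ncn(C4CCCCC4)c3c2)n1` gives 9.36%; compound 2 `c1ccc(-c2cn3ccnc3c(-c3ccc4ncn(C5CCCCC5)c4c3)n2)cc1` gives 33.3%; compound 3 `Clc1ccc(-c2cn3ccnc3c(-c3ccc4ncn(C5CCCCC5)c4c3)n2)cc1` gives 11.6%.

Compound 3 stands second of the three numbers. Its value and that of compound 1 lie within the scatter of each other, while compound 2 sits higher: a number 21.7 percentage points lower from compound 2 to compound 3 (beyond the scatter). The other step that bears here is a number 23.9 percentage points higher from compound 1 to compound 2 (beyond the scatter), whereas a number 2.2 percentage points higher from compound 1 to compound 3 (within the scatter).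

Compound 4 `COc1ccccc1-c1cn2ccnc2c(-c2ccc3ncn(C4CCCCC4)c3c2)n1` is not yet measured; it differs from compound 3 by 2-methoxyphenyl in place of 4-chlorophenyl on an aromatic carbon. Going by the values given here, no measured step carries a methoxy group, so the direction is uncertain. An unsubstituted phenyl gave the highest number, a chlorinated one fell back; a methoxy-bearing phenyl is therefore expected to land somewhere between, with a number 10.4 percentage points higher from compound 3 to compound 4 (beyond the scatter), giving an estimated 22% within 5% to 42%.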

Compound 4, a percentage reported as inhibition, at one concentration (the size of the read-out at that concentration, not a potency): 13.9%
Compound 4: middle estimate off by 8.1 percentage points, on the high side; the measured number falls inside the stated range.
By their numbers in this assay, from the lowest: compounds 1, 3 and 4 (each within the scatter of the next); then compound 2.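

In this assay, going by these compounds alone, a methoxy group on the phenyl also gives a lower number than the unsubstituted phenyl (a number 19.4 percentage points lower from compound 2 to compound 4 (beyond the scatter)), so the drop is no longer tied to chloro alone. 2-Methoxyphenyl cannot be told apart from 4-chlorophenyl (a number 2.3 percentage points higher from compound 3 to compound 4 (within the scatter)) or from bromo (a number 4.5 percentage points higher from compound 1 to compound 4 (within the scatter)), which leaves the unsubstituted phenyl of compound 2 as the only group here that stands apart. No evidence at hand explains this result.

The 2-methoxyphenyl and 4-chlorophenyl groups differ in both substituent and its place on the phenyl, so these two effects cannot be separated. Going by these compounds, how an amine or a carboxylic acid on that phenyl would read remains open.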